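Amide variation on a shared dihydroxy acid core

The compounds below may be only part of what the source reports. "The series", "measured", "known", "first", "only" and "open" are said of these compounds alone.

These notes concern a small set of amides built on one shared core, read in a functional assay on L6 cells (Rattus norvegicus) for inhibition; on this read-out higher numbers stand for weaker inhibition and lower numbers for stronger inhibition. Compound 1 `CC(C)c1c(C(=O)NCC2CCCCC2)nn(-c2ccc(F)cc2)c1OC[C@@H](O)C[C@@H](O)CC(=O)O` carries a (cyclohexylmethyl)amino group on its carbonyl carbon; in this assay compound 1 gives "not determined" (no result reported), so no single number stands for it, and compound 3 `COc1cc(CN(C)C(=O)c2nn(-c3ccc(F)cc3)c(OC[C@@H](O)C[C@@H](O)CC(=O)O)c2C(C)C)cc(OC)c1` likewise gives "not determined" (no result reported) in this assay. Only compound 2 `CC(C)c1c(C(=O)N2CCCCC2)nn(-c2ccc(F)cc2)c1OC[C@@H](O)C[C@@H](O)CC(=O)O` has been measured: in this assay compound 2 gives 32200 nM, a weak inhibition. Compound 1 therefore cannot be placed above or below any other entry on the numbers shown.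

Compound 4 `CC(C)c1c(C(=O)N(C)Cc2ccc(F)cc2)nn(-c2ccc(F)cc2)c1OC[C@@H](O)C[C@@H](O)CC(=O)O` is the next member; it differs from compound 1 as follows ((4-fluorobenzyl)(methyl)amino in place of (cyclohexylmethyl)amino on a carbonyl carbon). Within the data shown here, no step between measured compounds exists that could set a scale for this change, so the size and direction of the step from compound 1 to compound 4 in this assay are open; the only anchor is the weak result of compound 2, which shares the core and also lacks an amide hydrogen. On that basis compound 4 is expected to inhibit weakly, with an estimated value of 20000 nM in this assay, in a range from 4000 nM to 90000 nM.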

Compound 4, half-maximal inhibitory concentration: 2800 nM
Compound 4: middle estimate off by 7.1-fold (0.85 log units), on the high side, outside the stated range (below it).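

In this assay, exchanging piperidin-1-yl for (4-fluorobenzyl)(methyl)amino on a carbonyl carbon gives a 12-fold lower number from compound 2 to compound 4 (1.06 log units; beyond the scatter), so the group at this position clearly moves the read-out. Neither group carries the amide hydrogen, so a step of this size occurs on the shared core with no amide hydrogen on either side. No measurement at hand accounts for the step.

Steps involving compound 1 or compound 3 cannot be read, which leaves open how the (cyclohexylmethyl)amino group of compound 1 compares with the groups on the measured compounds. Also open, going by these compounds, is how a morpholin-4-yl group, or a longer chain such as (4-fluorophenethyl)(methyl)amino, on the same carbonyl carbon would read against the two measured amides.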